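The compounds below may be only part of what the source reports. "The series", "measured", "known", "first", "only" and "open" are said of these compounds alone.

In a functional assay on the whole organism for agonist activity, with Mus musculus as the target (a lower number here means that less compound is needed, a higher number that more compound is needed for the effect), compound 2 `COC(=O)N(C)CC#CCN1CCCC1` gives 5.5 mg/kg, the higher of the two numbers available in this set. The nearest value comes from compound 1 `CC(=O)N(C)CC#CCN1CCCC1` at 0.55 mg/kg. The measured step is a 10-fold higher number from compound 1 to compound 2 (1.00 log units; beyond the scatter), with methoxy in place of methyl on a carbonyl carbon. Compound 3 `COC(=O)N(C)CC#CCn1cncc1C` reads > 100 mg/kg, which is a limit of the assay and not a number.

Compound 4 `COC(=O)N(C)CC#CCN(C)C` carries dimethylamino in place of pyrrolidin-1-yl on a saturated chain carbon bound to a triple-bonded carbon. For the measured compounds named here, no measured step covers this place. Going by the values given here, the one measured step lies at the carbonyl carbon and bears only indirectly, as a guide to size: a single change took the series through a 10-fold higher number from compound 1 to compound 2 (1.00 log units; beyond the scatter). A somewhat smaller move towards a higher number in this assay is expected, with a wide range around it. The expected step is a 2.7-fold higher number from compound 2 to compound 4 (0.44 log units; beyond the scatter). For compound 4 the estimate is 15 mg/kg, with an expected range from 4 mg/kg to 60 mg/kg.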

Compound 4, dose for half-maximal effect: 14.3 mg/kg
Compound 4: the middle estimate sits 1.0-fold (0.02 log units) above what was measured; measured number inside the range.
By their numbers in this assay, from the lowest: compound 1; then compound 2; then compound 4. At a limit, above all of these: compound 3.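

The place on a saturated chain carbon bound to a triple-bonded carbon, unchanged between compound 1 and compound 2, now has a measured step of its own in this assay: dimethylamino in place of pyrrolidin-1-yl gives a 2.6-fold higher number from compound 2 to compound 4 (0.41 log units; beyond the scatter). Compound 4 has no ring at this place and still gives a readable dose, so in this series a ring there is not required for a numerical result. Compound 3, which differs from compound 2 at this same place, gives a limit of the assay and not a number: the limit of > 100 mg/kg in this assay, at which 1 of the 4 values shown sits.

The compounds shown do not separate the loss of the ring from the change in the count of heavy atoms; piperidin-1-yl or diethylamino at this place would bear on that. From the compounds shown here alone, it also remains open whether dimethylamino gives a similar step when methyl replaces methoxy on the carbonyl carbon, as in compound 1.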